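Chain length at the ring nitrogen: nonyl analogue

The compounds below may be only part of what the source reports. "The series", "measured", "known", "first", "only" and "open" are said of these compounds alone.

Measured compounds:
compound 1 `CCCCn1c(-c2cccc(Cl)c2)n[nH]c1=S` 77.8 mg/kg
compound 2 `CCCCCn1c(-c2cccc(Cl)c2)n[nH]c1=S` 65.2 mg/kg
compound 3 `CCCCCCCn1c(-c2cccc(Cl)c2)n[nH]c1=S` 65.2 mg/kg

In a functional assay on the whole organism (strain Swiss) with Mus musculus as the target, in the maximal electroshock model, with a stated time of 30 min (a lower number here means that less compound is needed, a higher number that more compound is needed for the effect), compound 1 gives the highest of the three numbers, yet its nearest and furthest neighbours, compound 2 and compound 3, lie within the scatter of it, so no order among the three can be claimed. Compound 4 `CCCCCCCCCn1c(-c2cccc(Cl)c2)n[nH]c1=S` carries the change (pentyl in place of hydrogen on a saturated chain carbon, four bonds along the chain from an aromatic nitrogen). Among the measured compounds shown here, the steps that bear on it are a 1.2-fold lower number from compound 1 to compound 2 (0.08 log units; within the scatter) and a 1.2-fold lower number from compound 1 to compound 3 (0.08 log units; within the scatter), with no change at the digits printed from compound 2 to compound 3 (within the scatter) between the two longer chains; each is within the scatter. Lengthening the chain at the same place further is therefore expected to give no step beyond the scatter in this assay, a 1.2-fold lower number from compound 1 to compound 4 (0.08 log units; within the scatter). Compound 4 is estimated at 65 mg/kg, with a range from 40 mg/kg to 110 mg/kg.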

Compound 4, dose for half-maximal effect: 130 mg/kg
The estimate for compound 4 lay 2.0-fold (0.30 log units) below the measured number; the measured number lies above the stated range.
By their numbers in this assay, from the lowest: compounds 2, 3, 1 and 4 (each within the scatter of the next).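

In this assay the nonyl chain gives a 1.7-fold higher number from compound 1 to compound 4 (0.22 log units; within the scatter) and a 2.0-fold higher number from compound 2 to compound 4 (0.30 log units; within the scatter) and a 2.0-fold higher number from compound 3 to compound 4 (0.30 log units; within the scatter) as its steps, so even this longest chain opens no gap beyond the scatter. The steps from compound 2 and compound 3 are the largest in the series and lie at the edge of the scatter, which hints at a rise at nonyl but does not establish one. Nothing available bears on the reason for this reading.

On these data alone, whether a longer chain such as dodecyl would step beyond the scatter stays open. So does the outcome of a terminal amine or carboxylic acid on the chain.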